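The source may hold more compounds than are shown below. What is called first, only, known or untested is meant among the compounds shown, and "the series" means these compounds.

Measured in a functional assay on HUVEC cells (Homo sapiens) for inhibition, using NADPH, with a stated time of 2 h; a lower number here means a stronger inhibitor, a higher number a weaker inhibitor:

- Compound 1 `CCCCCCCCCc1[nH]c2ccccc2c(=O)c1C`: 5.6 nM
- Compound 2 `COCCOCCCCc1[nH]c2ccccc2c(=O)c1C`: 460 nM
- Compound 3 `Cc1c(COCCCCOCC2(C)COC2)[nH]c2ccccc2c1=O`: 1200 nM

Compound 3, at 1200 nM, has the highest number of the three and so is the weakest inhibitor here. Compound 2 comes closest to it at 460 nM, a gap beyond the usual scatter, while compound 1 lies much further off at 5.6 nM.

The next compound to consider is compound 4 `Cc1c(COCCCCO)[nH]c2ccccc2c1=O`. It has hydrogen in place of (3-methyloxetan-3-yl)methyl on an oxygen on a saturated carbon, so the chain now ends in hydroxy: hydrogen in place of (3-methyloxetan-3-yl)methyl on an oxygen on a saturated carbon.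

Among the measured compounds shown here, only one measured step bears on this, and only loosely: an 82-fold higher number from compound 1 to compound 2 (1.91 log units; beyond the scatter). That large step also altered the far part of the chain, and it went towards a higher number. For the measured compounds named here, it involved different groups, however, and no measured compound carries a free hydroxy, so its size cannot simply be carried over. A much smaller move in the same direction seems the better expectation, with a wide margin. The expected step is a 2.5-fold higher number from compound 3 to compound 4 (0.40 log units; beyond the scatter). Compound 4 is estimated at 3000 nM, with an expected range of 700 nM to 12000 nM.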

Compound 4, half-maximal inhibitory concentration: 2600 nM
Compound 4: the middle estimate sits 1.2-fold (0.06 log units) above what was measured; the measured number falls inside the stated range.
By their numbers in this assay, from the lowest: compound 1; then compound 2; then compound 3; then compound 4.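

Cutting the (3-methyloxetan-3-yl)methyl group from the oxygen at the end of the chain, so that the chain now ends in hydroxy, gives a 2.2-fold higher number from compound 3 to compound 4 (0.34 log units; beyond the scatter) in this assay. Among the compounds shown here, this is the first look at this oxygen, and it shows that a whole group carrying a four-membered ring can be removed there for only a modest change, much less than the large change seen at a different part of the chain, an 82-fold higher number from compound 1 to compound 2 (1.91 log units; beyond the scatter). No measurement shown here explains why the number rises when this group is lost.

The two compounds alone cannot separate the part played by the four-membered ring from that of the carbons linking it to the oxygen, and a simple methyl group on that oxygen, or an open-chain ether of similar length, would help to tell these apart. Going by these compounds, how the number would respond if an amine or a carboxylic acid took the place of the hydroxy at the chain end also remains open.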